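The compounds below may be only part of what the source reports. "The series", "measured", "known", "first", "only" and "open" are said of these compounds alone.

In a functional assay on EJ1 cells (Homo sapiens) for cytotoxicity, read by WST assay, with a stated time of 72 h (on this read-out lower numbers stand for stronger inhibition and higher numbers for weaker inhibition), compound 1 `CC1=CC(=O)C[C@H]2[C@](C)(CC/C(C)=C/C[n+]3cn(C)c4ncnc(N)c43)[C@@H](C)CC[C@@]12C` is reported only as a limit, > 50000 nM. Compound 2 `CC1=CCC[C@H](C)[C@@]1(C)CCC(C)(O)CCC/C(C)=C/C[n+]1cn(C)c2ncnc(N)c21` is also reported only as a limit, > 50000 nM. Among the measured compounds shown here, compound 3 `CC1=CCC[C@H]2[C@](C)(CC/C(C)=C/Cn3c[n+](C)c4ncnc(N)c43)[C@@H](C)CC[C@@]12C` gives 42000 nM, the only true number among the three, and a weak result on this scale. Compound 4 `CC1=CCC[C@@H]2[C@@](C)(CC/C(C)=C/Cn3c[n+](C)c4ncnc(N)c43)[C@H](C)CC[C@@]12C` is built from the same pieces, and the change is purely one of three-dimensional arrangement: the two compounds have the same atoms and bonds and differ only in configuration as drawn: 3 of 5 stereo elements differ; a stereocentre at a saturated ring carbon is drawn S in compound 3 and R in compound 4; a stereocentre at a saturated ring carbon is drawn R in compound 3 and S in compound 4; a stereocentre at a saturated ring carbon is drawn S in compound 3 and R in compound 4. Nothing is added or removed, and three saturated ring carbons simply swap their drawn configuration. For the measured compounds named here, no measured step shows what such a swap does, so the expectation is of no change beyond the usual scatter, an estimated 1.1-fold lower number from compound 3 to compound 4 (0.02 log units; within the scatter). Compound 4 is expected to give about 40000 nM, within an estimated range of 15000 nM to 60000 nM.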

Compound 4, half-maximal inhibitory concentration: 19000 nM
For compound 4 the middle estimate is 2.1-fold (0.32 log units) above the measured one; low and high end bracket the measured number.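

In this assay, among the compounds shown here, the swap at the three saturated ring carbons gives a 2.2-fold lower number from compound 3 to compound 4 (0.34 log units; beyond the scatter), a modest step and the first comparison that can be read in this set. It can be put down to three-dimensional arrangement alone, for one reason: the fact that compounds 3 and 4 differ only in the configuration as drawn. Compounds 1 and 2 could not show this, as each gives only a limit and no true number: the limit of > 50000 nM in this assay, at which 2 of the 4 values shown sit.

As far as these compounds go, the share of each of the three carbons in this step stays open. So does the effect of a carboxylic acid added to the shared core.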